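A dichlorophenyl swap in a growth inhibition series

The source may report more compounds than this note shows. Statements on the series, on what has been measured and on what is new or still open speak of the compounds shown alone.

- Compound 1 `O=C(/C(=C\c1cccc(Cl)c1Cl)SCc1ccc(Cl)cc1)c1ccc(Cl)cc1` gives 10000 nM
- Compound 2 `Cc1ccc(CS/C(=C/c2ccc(Cl)cc2)C(=O)c2ccc(Cl)cc2)cc1` gives 10000 nM

In a functional assay on DU-145 cells (Homo sapiens) for inhibition, read by trypan blue exclusion, with a stated time of 96 h (a higher number here means a weaker inhibitor of growth, a lower number a stronger inhibitor of growth), compound 2 gives 10000 nM and so stands level with compound 1. Compound 3 `Cc1ccc(CS/C(=C/c2cccc(Cl)c2Cl)C(=O)c2ccc(Cl)cc2)cc1` differs from compound 2 by a single swap 2,3-dichlorophenyl in place of 4-chlorophenyl on a double-bonded chain carbon bound to a double-bonded chain carbon and the rest of the structure stays the same. The incoming 2,3-dichlorophenyl is already present in compound 1, which gives 10000 nM and so offers no sign of a gain or a loss. The expected step of a 1.1-fold lower number from compound 2 to compound 3 (0.05 log units; within the scatter) is therefore none beyond the scatter. The estimated value for compound 3 is 9000 nM with an expected range from 3500 nM to 20000 nM in this measurement.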

Compound 3, concentration for 50% growth inhibition: 25000 nM
Compound 3: the middle estimate sits 2.8-fold (0.44 log units) below what was measured; the measured number lies above the stated range.
By their numbers in this assay, from the lowest: compounds 1 and 2 (each within the scatter of the next); then compound 3.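

In this assay the swap to 2,3-dichlorophenyl gives a 2.5-fold higher number from compound 2 to compound 3 (0.40 log units; beyond the scatter) and so weakens growth inhibition, which shows that this position on a double-bonded chain carbon does respond to the change. The methyl in place of chloro on an aromatic carbon gives a 2.5-fold higher number from compound 1 to compound 3 (0.40 log units; beyond the scatter) and so makes the same group's effect depend on that second site, a link that the level values of the earlier pair could not reveal. Nothing measured here explains either step.

Going by these compounds, whether an amine or a methoxy group on that aromatic carbon would give stronger or weaker growth inhibition remains open. So does the effect of a single chloro group elsewhere on the ring at the double-bonded chain carbon.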